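The source may hold more compounds than are shown below. What is called first, only, known or untested is meant among the compounds shown, and "the series" means these compounds.

Compound 1, `O=C(/N=C(/NC(=O)c1cc(-c2ccccc2)nc2ccccc12)[Se]Cc1ccccc1)c1cc(-c2ccccc2)nc2ccccc12`, is one of a small set of selenium-bearing compounds tested in an ADME assay on MCF-10A cells (Homo sapiens) for cytotoxicity, read by MTT assay, with a stated time of 72 h (on this read-out lower numbers stand for stronger inhibition of growth and higher numbers for weaker inhibition of growth), where compound 1 gives 45600 nM. Compound 2, `C[Se]/C(=N\C(=O)c1cc(-c2ccccc2)nc2ccccc12)NC(=O)c1cc(-c2ccccc2)nc2ccccc12`, differs from compound 1 by a single change, (hydrogen in place of phenyl on a saturated chain carbon bound to a selenium atom), and in this assay compound 2 gives 20100 nM, so that the change makes a 2.3-fold lower number from compound 1 to compound 2 (0.36 log units; beyond the scatter).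

Compound 3, `O=C(/N=C(/NC(=O)c1csc([N+](=O)[O-])c1)[Se]Cc1ccccc1)c1csc([N+](=O)[O-])c1`, is built on a different core; the difference between the core of compound 1 and the core of compound 3 is not broken down here. In this assay compound 3 gives 54100 nM, which lies within the scatter of the value of compound 1, and which stands a little beyond the scatter above the value of compound 2.

Compound 4, `C[Se]/C(=N\C(=O)c1csc([N+](=O)[O-])c1)NC(=O)c1csc([N+](=O)[O-])c1`, has not been measured. It is related to compound 3 by hydrogen in place of phenyl on a saturated chain carbon bound to a selenium atom, the same change that separates compound 1 from compound 2, at the same place, and this change is seen in two pairs among the compounds shown. Resting on the step it made from compound 1 to compound 2, a 2.3-fold lower number from compound 1 to compound 2 (0.36 log units; beyond the scatter), compound 4 is expected to show a step of a 2.1-fold lower number from compound 3 to compound 4 (0.32 log units; beyond the scatter) in this assay. Compound 4 is therefore estimated at 26000 nM, with a likely range from 14000 nM to 50000 nM.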

Compound 4, concentration for total growth inhibition: 4740 nM
Estimate against measurement, compound 4: 5.5-fold (0.74 log units) above; measured number outside the range, below it.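

The change of hydrogen in place of phenyl on a saturated chain carbon bound to a selenium atom lowers the number on both cores, and in this assay it makes an 11-fold lower number from compound 3 to compound 4 (1.06 log units; beyond the scatter). Set side by side, the two steps agree in direction but not in size, so the step seen on one core does not give the size of the step on the other: the same change on two cores in this assay, a 2.3-fold lower number (0.36 log units; beyond the scatter) from compound 1 to compound 2 and an 11-fold lower number (1.06 log units; beyond the scatter) from compound 3 to compound 4, 5.0-fold (0.70 log units) apart, beyond the scatter of two such steps

These two pairs do not show why the step is larger on one core, and they give no rule for the size of the step on any further core.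

The compounds shown carry only benzyl and methyl at this place, which leaves open what a longer chain such as propyl, or a chain ending in an amine or a carboxylic acid, would do there. For the compounds shown here, they also span only two cores, so it stays open which part of the core goes with the larger step.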